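The source may hold more compounds than are shown below. What is called first, only, known or untested is meant among the compounds shown, and "the series" means these compounds.

Compound 3 `O=C(CSc1nnnn1-c1ccccc1)N/N=c1/scc(-c2ccc(Cl)cc2)n1-c1ccccc1` gives 69.3% in a functional assay on C6 cells (Rattus norvegicus) for cytotoxicity, read by MTT assay, with a stated time of 24 h, tested at 12 ug/mL (on this read-out lower numbers stand for a stronger effect and higher numbers for a weaker effect at the one concentration tested), the second highest of three numbers. Compound 1 `O=C(CSc1nnnn1-c1ccccc1)N/N=c1/scc(-c2ccc(Br)cc2)n1-c1ccccc1` gives 58.6%, and the step of a number 10.7 percentage points higher from compound 1 to compound 3 (beyond the scatter) comes with chloro in place of bromo on an aromatic carbon. Compound 2 `Cc1nnc(SCC(=O)N/N=c2/scc(-c3ccc(Cl)cc3)n2-c2ccccc2)s1` gives 76.6%, and the step of a number 7.3 percentage points lower from compound 2 to compound 3 (within the scatter) comes with 1-phenyl-1H-tetrazol-5-yl in place of 5-methyl-1,3,4-thiadiazol-2-yl on a sulfur. Compound 4 `O=C(CSc1ncccn1)N/N=c1/scc(-c2ccc(Cl)cc2)n1-c1ccccc1` differs from compound 3 by pyrimidin-2-yl in place of 1-phenyl-1H-tetrazol-5-yl on a sulfur. For the measured compounds named here, only the step from compound 2 to compound 3 bears on this change, a second exchange of the group on the sulfur, and it stayed within the scatter, so no step beyond the scatter is expected in this assay. Compound 4 is estimated at 70%, between 55% and 85%, with a number 0.7 percentage points higher from compound 3 to compound 4 (within the scatter) expected.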

Compound 4, a percentage reported as activity, at one concentration (the size of the read-out at that concentration, not a potency): 91.6%
Compound 4: the middle estimate sits 21.6 percentage points below what was measured; measured number above the stated range.
By their numbers in this assay, from the lowest: compound 1; then compounds 3 and 2 (each within the scatter of the next); then compound 4.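

In this assay the group on the sulfur can move the read-out beyond the scatter: pyrimidin-2-yl brings a number 22.3 percentage points higher from compound 3 to compound 4 (beyond the scatter) and a number 15 percentage points higher from compound 2 to compound 4 (beyond the scatter), a weaker effect at the one concentration tested. Compounds 2 and 3, with their five-membered aromatic rings on the sulfur, stay within the scatter of each other, and compound 4, with its six-membered ring there, stands apart from both. No measurement here accounts for this.

Still open, going by these compounds, is whether the step from the tetrazole to the pyrimidine holds with bromo in place of chloro on the aromatic carbon. Also open, on these data alone, is how a pyridin-2-yl group or a chain ending in a carboxylic acid on the sulfur would read.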